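Chalcone-linked pyrazole amides: aryl variation on the enone chain

A few compounds are considered here, and "the series" means these few. Any claim that something is new, unique, unknown or untested is made for them only; others in the source may bear on it.

In a functional assay, read by spectrophotometry, tested at 100 uM (on this read-out lower numbers stand for stronger inhibition and higher numbers for weaker inhibition), compound 1 `O=C(/C=C/c1cccc2ccccc12)c1cccc(NC(=O)c2cc(-c3ccncc3)n[nH]2)c1` gives 72100 nM, and compound 2 `O=C(/C=C/c1cccs1)c1cccc(NC(=O)c2cc(-c3ccncc3)n[nH]2)c1` gives 70000 nM. The step of a 1.0-fold lower number from compound 1 to compound 2 (0.01 log units; within the scatter) shows that exchanging the aryl group on the enone chain left the read-out essentially unchanged. Compound 2 stands at the lowest of the two numbers in this assay, though the gap to compound 1 lies within the scatter, so no order can be drawn between them.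

Compound 3 `COc1cc(/C=C/C(=O)c2cccc(NC(=O)c3cc(-c4ccncc4)n[nH]3)c2)cc(OC)c1OC` is not yet measured in this assay. It differs from compound 2 as follows: 3,4,5-trimethoxyphenyl in place of thiophen-2-yl on a double-bonded chain carbon bound to a double-bonded chain carbon. Among the compounds with values here, the one measured step that bears on this change is a 1.0-fold lower number from compound 1 to compound 2 (0.01 log units; within the scatter), which concerned the same place on the chain and produced nothing beyond the scatter. The step of no change at the digits printed from compound 2 to compound 3 (within the scatter) is therefore expected to stay within the scatter as well. Compound 3 is estimated at 70000 nM in this assay, with a range from 20000 nM to 250000 nM.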

Compound 3, half-maximal inhibitory concentration: 52900 nM
Compound 3: middle estimate off by 1.3-fold (0.12 log units), on the high side; low and high end bracket the measured number.
By their numbers in this assay, from the lowest: compounds 3, 2 and 1 (each within the scatter of the next).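

In this assay, the exchange of thiophen-2-yl for 3,4,5-trimethoxyphenyl raises the group from 5 to 12 heavy atoms and from 1 to 3 hydrogen-bond acceptors, yet the step is a 1.3-fold lower number from compound 2 to compound 3 (0.12 log units; within the scatter). Against the fused aromatic group, the step is a 1.4-fold lower number from compound 1 to compound 3 (0.13 log units; within the scatter), so this place on the chain now shows three different aromatic groups with no difference beyond the scatter. No supporting data bear on why the read-out stays flat across these groups.

On these data alone, all three compounds carry an aromatic ring at this place, so it remains open whether a non-aromatic group there, such as an amine, a carboxylic acid or a longer alkyl chain, would move the number beyond the scatter. The shared core is also constant throughout, which leaves the effect of any change elsewhere unresolved.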